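The source may hold more compounds than are shown below. What is called first, only, known or untested is meant among the compounds shown, and "the series" means these compounds.

Values so far in a functional assay on HCT-15 cells (Homo sapiens) for antiproliferative activity, read by MTT assay, with a stated time of 72 h (a lower number here means a stronger inhibitor, a higher number a weaker inhibitor), are these
- compound 1 `COc1ccc(-n2ccnc2-c2cc(OC)c(OC)c(OC)c2)cc1[N+](=O)[O-]` gives 1000 nM
- compound 2 `COc1cc(-c2nccn2-c2cccc(C)c2)cc(OC)c1OC` gives 1600 nM
- compound 3 `COc1cccc(-n2ccnc2-c2cc(OC)c(OC)c(OC)c2)c1` gives 17100 nM

Compound 3 has the highest number of the three, and its gap to each of the other two lies beyond the scatter. That makes it the weakest inhibitor measured so far. Compound 4 `COc1cc(-c2nccn2-c2cccc([N+](=O)[O-])c2)cc(OC)c1OC` has no value yet. It differs from compound 3 by one swap, nitro in place of methoxy on an aromatic carbon, meta to a large group (nitro in place of methoxy on an aromatic carbon).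

Going by the values given here, only one measured step involves the methoxy group that leaves. This is an 11-fold higher number from compound 2 to compound 3 (1.03 log units; beyond the scatter), a large step with methoxy in place of methyl. Among the compounds with values here, no measured step swaps methoxy for nitro, so this evidence is indirect. The closest guide is compound 1 at 1000 nM, which also holds a nitro but carries a further methoxy that compound 4 lacks. Together, these two comparisons suggest that removing the methoxy could recover much of the gap, though a single step is thin support.

The expected change is a 5.7-fold lower number from compound 3 to compound 4 (0.76 log units; beyond the scatter), a move to a lower number beyond the scatter. For compound 4 the estimate is 3000 nM, with an expected range from 800 nM to 11000 nM as the uncertainty.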

Compound 4, half-maximal inhibitory concentration: > 100000 nM
Compound 4: only a limit was reported; the forecaster's own chance of this, stated with the estimate: 3%; at least 33-fold (1.52 log units) between middle value and limit.
By their numbers in this assay, from the lowest: compounds 1 and 2 (each within the scatter of the next); then compound 3. At a limit, above all of these: compound 4.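

In this assay a nitro on this aromatic carbon, meta to a large group, gives the weakest result of the four compounds, with an at least 5.8-fold higher number from compound 3 to compound 4 (0.76 log units; beyond the scatter) and an at least 62-fold higher number from compound 2 to compound 4 (1.79 log units; beyond the scatter) as its steps from the methoxy and the methyl. The earlier compounds shown here suggested that a nitro could go with a low number, but an at least 100-fold higher number from compound 1 to compound 4 (2.00 log units; beyond the scatter) shows that the nitro alone does not bring one, since that step is the loss of the further methoxy that compound 1 carries. All three of these steps end at a limit and not at a number: the limit of > 100000 nM in this assay, at which 1 of the 4 values shown sits.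

The compounds shown leave open why the methyl of compound 2 at 1600 nM stands so far from the nitro, and nothing here gives a cause for that gap. They also leave open what an amine, a chlorine atom or a longer chain would do on this same carbon, and whether the further methoxy of compound 1 would change the number for any group other than the nitro.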